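The compounds below may be only part of what the source reports. "The series", "measured", "known", "first", "only" and "open" are said of these compounds alone.

Measured compounds:
- compound 1 `CN(C)CCN1CCN(CC(=O)Nc2ccc(-c3nc4cc(Cl)ccc4o3)cc2)CC1` gives 7100 nM in a functional assay on A549 cells (Homo sapiens) for cytotoxicity, read by MTT assay, with a stated time of 24 h; a lower number here means a stronger inhibitor, a higher number a weaker inhibitor
- compound 2 `CN(C)CCN1CCN(CC(=O)Nc2ccc(-c3nc4ccccc4o3)cc2)CC1` gives 18700 nM in this assay
- compound 3 `Cc1cc(-c2nc3cc(Cl)ccc3o2)ccc1NC(=O)CN1CCN(CCN(C)C)CC1` gives 24400 nM in this assay

Among these three, compound 1 holds the lowest number. Its nearest neighbour is compound 2, reached by a 2.6-fold higher number from compound 1 to compound 2 (0.42 log units; beyond the scatter), with hydrogen in place of chloro on an aromatic carbon. Further off stands compound 3, reached by a 3.4-fold higher number from compound 1 to compound 3 (0.54 log units; beyond the scatter), with methyl in place of hydrogen on an aromatic carbon. Both steps move the number upward by a modest amount that lies beyond the scatter.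

Compound 4 `CN(C)CCCN1CCN(CC(=O)Nc2ccc(-c3nc4cc(Cl)ccc4o3)cc2)CC1` has not yet been measured. It differs from compound 1 by (dimethylamino)methyl in place of dimethylamino on a saturated chain carbon, two bonds along the chain from an amine nitrogen in a ring. Neither of the measured steps touches this part of the molecule: the step to compound 2 and the step to compound 3 both alter aromatic substituents, whereas the change to compound 4 lengthens the saturated chain by one carbon. Going by the values given here, no measured pair therefore speaks directly to this change. With nothing to point either way, the expectation for compound 4 is a number close to that of compound 1, a step of a 1.1-fold higher number from compound 1 to compound 4 (0.02 log units; within the scatter) that is not expected to exceed the scatter. The estimate for compound 4 is 7500 nM, within a range from 3000 nM to 19000 nM.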

Compound 4, half-maximal inhibitory concentration: 4320 nM
Compound 4: middle estimate off by 1.7-fold (0.24 log units), on the high side, within the range that was stated.
By their numbers in this assay, from the lowest: compounds 4 and 1 (each within the scatter of the next); then compounds 2 and 3 (each within the scatter of the next).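

The swap of dimethylamino for (dimethylamino)methyl on a saturated chain carbon, two bonds along the chain from an amine nitrogen in a ring, gives a 1.6-fold lower number from compound 1 to compound 4 (0.22 log units; within the scatter) in this assay and so leaves the two compounds indistinguishable in this read-out. Going by these compounds alone, the earlier steps, a 2.6-fold higher number from compound 1 to compound 2 (0.42 log units; beyond the scatter) and a 3.4-fold higher number from compound 1 to compound 3 (0.54 log units; beyond the scatter), both concerned aromatic carbons and lay beyond the scatter, so this is the first reading from the saturated chain, and it shows that 2-(dimethylamino)ethyl and 3-(dimethylamino)propyl cannot be separated here. No measurement offered here accounts for this result.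

The compounds shown cover only these two chains, so they leave open whether a longer chain ending in dimethylamino, or a chain ending in a primary amine or a pyrrolidine, would stay level with compound 1 or move away from it. They also leave open whether removing the chloro group or adding the methyl group would produce steps of the same size on the 3-(dimethylamino)propyl chain as on the 2-(dimethylamino)ethyl chain.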